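Cytotoxicity notes on the alkoxy and alkylsulfanyl series

A few compounds are considered here, and "the series" means these few. Any claim that something is new, unique, unknown or untested is made for them only; others in the source may bear on it.

Compound 1 `CCCCCCCCOc1nc(N)nc2c1ncn2/C=C1/CC1(CO)CO` and compound 2 `CCCCSc1nc(N)nc2c1ncn2/C=C1/CC1(CO)CO` share a core with compound 3 `CN(C)c1nc(N)nc2c1ncn2/C=C1/CC1(CO)CO` and differ from each other only at one aromatic carbon. In an ADME assay on MOLT-3 cells (Homo sapiens) for cytotoxicity, with a stated time of 7 days (a higher number here means that more compound is tolerated, a lower number that less compound is tolerated), compound 1 reaches only a limit of the assay, > 20000 nM. Compound 2 likewise reaches only a limit, > 20000 nM. The step that the two limits leave unreadable from compound 1 to compound 2 is therefore unreadable. Compound 3 stands outside the numbers: in this assay compound 3 is "not determined" (no result reported). The unmeasured compound 4 `CC(C)Sc1nc(N)nc2c1ncn2/C=C1/CC1(CO)CO` differs from compound 3 by isopropylsulfanyl in place of dimethylamino on an aromatic carbon. Within the data shown here, no measured step touches this change, and both readable values sit at the limit of > 20000 nM in this assay, at which 2 of the 3 values shown sit. Compound 4 is therefore expected to tolerate a large amount, estimated at 30000 nM with a range of 10000 nM to 100000 nM, most likely reported as a limit.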

Compound 4, half-maximal cytotoxic concentration: > 20000 nM
Compound 4 ended at the assay's limit; the forecaster's own chance of this, stated with the estimate: 80%; the middle value is on the limit's open side.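

In this assay, among these compounds, compound 4 reaches only a limit, > 20000 nM, so no step among compound 1, compound 2 and compound 4 can be read. The compounds shown leave open whether the group on the aromatic carbon shifts tolerance at all.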